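The compounds below may be only part of what the source reports. "The series", "measured", "known", "first", "only" and "open" are said of these compounds alone.

Compound 1 `Nc1ncc(-c2ccc(C(=O)N3CC(O)C3)cc2)nc1-c1ccc(C(F)(F)F)cc1`: 55000 nM
Compound 2 `NC(=O)c1ccc(-c2cnc(N)c(-c3ccc(C(F)(F)F)cc3)n2)cc1`: < 5000 nM, a limit
Compound 3 `Nc1ncc(-c2ccc(C(=O)O)cc2)nc1-c1ccc(C(F)(F)F)cc1`: 95000 nM

All three were read in a physicochemical assay for solubility, read by HPLC, using the shake flask method, in phosphate buffer, with a stated time of 2 h, at pH 6.5; a lower number here means a less soluble compound, a higher number a more soluble compound. Compound 1 and compound 3 lie within the scatter of each other, and the measured step is a 1.7-fold higher number from compound 1 to compound 3 (0.24 log units; within the scatter). Both stand well clear of the remaining compound, as an at least 11-fold lower number from compound 1 to compound 2 (1.04 log units; beyond the scatter) and an at least 19-fold higher number from compound 2 to compound 3 (1.27 log units; beyond the scatter) show.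

Compound 4 `Nc1ncc(-c2ccc(C(=O)N3CCC(N)C3)cc2)nc1-c1ccc(C(F)(F)F)cc1` has 3-aminopyrrolidin-1-yl in place of hydroxy on a carbonyl carbon. All three measured steps are changes at this same carbonyl carbon, and they point two ways. Exchange of hydroxy for a ring-bearing group has a measured precedent in compound 1, with no change beyond the scatter. Compound 2, which has amino there, goes against this and shows that a large drop is possible at this place. Compound 1 is taken as the closer guide, since its group also has a ring on the carbonyl carbon.

The expected step is a 1.4-fold lower number from compound 3 to compound 4 (0.13 log units; within the scatter), so no change beyond the scatter is expected. Compound 4 is estimated at 70000 nM, with an expected range of 20000 nM to 200000 nM.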

Compound 4, solubility: 102000 nM
Beside the measured number, compound 4's estimate is 1.5-fold (0.16 log units) below it, and the stated range covers the measured number.
By their numbers in this assay, from the lowest: compounds 1, 3 and 4 (each within the scatter of the next). At a limit, below all of these: compound 2.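

In this assay, a second ring-bearing group on the carbonyl carbon sits level with both the carboxy group, a 1.1-fold higher number from compound 3 to compound 4 (0.03 log units; within the scatter), and the 3-hydroxyazetidin-1-yl group, a 1.9-fold higher number from compound 1 to compound 4 (0.27 log units; within the scatter). Among the compounds shown, the large drop at this place thus stays confined to amino on the carbonyl carbon, an at least 20-fold higher number from compound 2 to compound 4 (1.30 log units; beyond the scatter). Compound 2 is read only as a limit: the limit of < 5000 nM in this assay, at which 1 of the 4 values shown sits.

Open, from the compounds shown here alone, is whether a pyrrolidin-1-yl group without the amino group, or a six-membered ring such as piperidin-1-yl or morpholin-4-yl, would stay at this level. Also open, going by these compounds, is whether a secondary amide with a short alkyl chain on its nitrogen would fall with compound 2 or with the ring-bearing compounds, which would help separate the role of the ring from that of the amide hydrogen.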